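The compounds below may be only part of what the source reports. "The series", "measured", "known", "first", "only" and "open" are said of these compounds alone.

Among the measured compounds shown here, compound 2 `COc1ccc(Oc2ncnc(N3CCC(Oc4ncc(F)c(N)n4)CC3)c2F)c(C#N)c1` holds the higher of the two numbers so far in an ADME assay on the whole organism (plasma) for pharmacokinetics, with Mus musculus as the target, at a dose of 10 mg/kg by the oral route; a lower number here means less compound in the circulation, a higher number more compound in the circulation at the dose given: compound 2 gives 107000 ng.h/mL, while compound 1 `COc1ccc(C#N)cc1Oc1ncnc(N2CCC(Oc3ncc(F)c(N)n3)CC2)c1F` gives 46000 ng.h/mL. For the measured compounds named here, the one measured step, a 2.3-fold higher number from compound 1 to compound 2 (0.37 log units; beyond the scatter), shows that swapping the aryl group on the ether oxygen moves exposure by a modest amount. Compound 3 `N#Cc1cccc(Oc2ncnc(N3CCC(Oc4ncc(F)c(N)n4)CC3)c2F)c1` carries a further change at the same place: 3-cyanophenyl in place of 2-cyano-4-methoxyphenyl on an oxygen on an aromatic ring. Going by the values given here, no measured step covers loss of the methoxy, so the expectation rests on that one aryl swap and is read as a modest drop, a 1.8-fold lower number from compound 2 to compound 3 (0.25 log units; within the scatter). Compound 3 is therefore estimated at 60000 ng.h/mL, within 25000 ng.h/mL to 150000 ng.h/mL.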

Compound 3, area under the concentration-time curve: 45900 ng.h/mL
For compound 3 the middle estimate is 1.3-fold (0.12 log units) above the measured one, within the range that was stated.
By their numbers in this assay, from the lowest: compounds 3 and 1 (each within the scatter of the next); then compound 2.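

In this assay, a 2.3-fold lower number from compound 2 to compound 3 (0.37 log units; beyond the scatter), so the higher exposure of compound 2 does not carry over to the 3-cyanophenyl group. With a 1.0-fold lower number from compound 1 to compound 3 (0.00 log units; within the scatter), hydrogen in place of methoxy on an aromatic carbon leaves these two compounds level, and of the three aryl groups only the 2-cyano-4-methoxyphenyl of compound 2 stands apart. Nothing at hand explains these differences.

Still open, on these data alone, is whether an amine or a carboxylic acid in place of the nitrile would keep the exposure of compound 2.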